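Pyridin-2-yl on the amide nitrogen: the step to compound 3

A few compounds are considered here, and "the series" means these few. Any claim that something is new, unique, unknown or untested is made for them only; others in the source may bear on it.

In an ADME assay on MRC5 cells (Homo sapiens) for inhibition, with a stated time of 72 h (a higher number here means that more compound is needed for the effect, a lower number that less compound is needed), compound 1 (`COc1cccc(OC)c1C(=O)Nc1c[nH]nc1C(=O)NCc1ccccc1`) gives 50000 nM as its value. Compound 2 (`COc1cccc(OC)c1C(=O)Nc1c[nH]nc1C(=O)NCc1ncccc1C`) gives > 50000 nM as its reading, and that reading is a limit of the assay and not a number. The picture so far is the limit of > 50000 nM in this assay, at which 1 of the 2 values shown sits, and compound 2 has no exact place on the scale. Among the compounds with values here, the only measured step is a number no lower from compound 1 to compound 2 (the limit leaves the size open) and it exchanges phenyl for 3-methylpyridin-2-yl on a saturated chain carbon, so its size stays open.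

Compound 3 (`COc1cccc(OC)c1C(=O)Nc1c[nH]nc1C(=O)Nc1ccccn1`) is still to be measured. It differs from compound 2 by pyridin-2-yl in place of (3-methylpyridin-2-yl)methyl on an amide-type nitrogen with pyridin-2-yl in place of (3-methylpyridin-2-yl)methyl on an amide-type nitrogen. Within the data shown here, no measured step covers this change directly. Among the measured compounds shown here, with compound 1 at 50000 nM as the only exact number, no large step is expected in this assay and any move should be small and toward a lower number. The expected move is an at least 1.2-fold lower number from compound 2 to compound 3 (0.09 log units; that floor lies within the scatter) on this estimate. For compound 3 the estimated value is 40000 nM with an expected range from 12000 nM to 50000 nM and a reading at the limit remains likely.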

Compound 3, half-maximal effective concentration: > 50000 nM
Compound 3 ended at the assay's limit; the forecaster's own chance of this, stated with the estimate: 60%; at least 1.2-fold (0.09 log units) between middle value and limit.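

In this assay, compound 3 gives > 50000 nM, which is a limit of the assay and not a number. The new reading gives a number no lower from compound 1 to compound 3 (the limit leaves the size open). On the amide-type nitrogen, pyridin-2-yl thus leaves the reading at the limit, as (3-methylpyridin-2-yl)methyl did, so a second group at this position has failed to give an exact number. The step from compound 2 to compound 3 cannot be read in size, and the readings now gather at one point on the scale: the limit of > 50000 nM in this assay, at which 2 of the 3 values shown sit.

Within the data shown here, how far compound 2 and compound 3 lie from the one exact number, that of compound 1, stays open. Also open, on these data alone, is whether an amine, a carboxylic acid or a longer chain on this amide-type nitrogen would give a reading that can be placed on the scale.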